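A few compounds are considered here, and "the series" means these few. Any claim that something is new, unique, unknown or untested is made for them only; others in the source may bear on it.

Three compounds have been measured in an assay on isolated protein for binding affinity to secreted frizzled-related protein 1 (Homo sapiens), read by fluorescence; a higher number here means a weaker inhibitor, a lower number a stronger inhibitor:

Compound 1 `CN(C)CC(=O)N1CCC(NS(=O)(=O)c2cc(S(=O)(=O)c3ccccc3)ccc2C(F)(F)F)CC1`: 300 nM
Compound 2 `O=C(CN1CCCC1)N1CCC(NS(=O)(=O)c2cc(S(=O)(=O)c3ccccc3)ccc2C(F)(F)F)CC1`: 110 nM
Compound 3 `O=C(Cn1ccnc1)N1CCC(NS(=O)(=O)c2cc(S(=O)(=O)c3ccccc3)ccc2C(F)(F)F)CC1`: 30 nM

The three share one core and differ only in the amine on a saturated chain carbon bound to a carbonyl carbon. The measured steps are a 2.7-fold lower number from compound 1 to compound 2 (0.44 log units; beyond the scatter), a 10-fold lower number from compound 1 to compound 3 (1.00 log units; beyond the scatter) and a 3.7-fold lower number from compound 2 to compound 3 (0.56 log units; beyond the scatter). Compound 2 therefore holds the second highest number of the three: compound 1 is nearest to it, with the higher number, and compound 3 is furthest, with the lower one.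

Compound 4 `CC(C)(C)CCN1CCC[C@H]1C(=O)N1CCC(NS(=O)(=O)c2cc(S(=O)(=O)c3ccccc3)ccc2C(F)(F)F)CC1` is the next compound to be measured. Relative to compound 2 the change is 1-(3,3-dimethylbutyl)pyrrolidin-2-yl in place of (pyrrolidin-1-yl)methyl on a carbonyl carbon. None of the three measured steps bears directly on this change: each of them exchanges one amine for another on the saturated chain carbon, whereas here the carbonyl carbon gains a ring carbon of a 1-(3,3-dimethylbutyl)pyrrolidin-2-yl group with a defined stereocentre. The measured steps only show that changes at this end of the molecule have moved the number by modest amounts in either direction. On that basis a step of a 1.4-fold higher number from compound 2 to compound 4 (0.13 log units; within the scatter) is expected, with the direction uncertain. Compound 4 is thus estimated at 150 nM, with a range from 40 nM to 600 nM.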

Compound 4, half-maximal inhibitory concentration: 30 nM
Beside the measured number, compound 4's estimate is 5.0-fold (0.70 log units) above it; measured number below the stated range.
By their numbers in this assay, from the lowest: compounds 3 and 4 (each within the scatter of the next); then compound 2; then compound 1.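

Compound 4 shows that the carbonyl carbon can carry a ring carbon of 1-(3,3-dimethylbutyl)pyrrolidin-2-yl, a group with more heavy atoms and a defined stereocentre, in place of (pyrrolidin-1-yl)methyl, with a 3.7-fold lower number from compound 2 to compound 4 (0.56 log units; beyond the scatter) in this assay rather than a loss. The earlier compounds shown here varied only the amine on the saturated chain carbon, and among them only the 1H-imidazol-1-yl group of compound 3 reached this level: the new group gives a 10-fold lower number from compound 1 to compound 4 (1.00 log units; beyond the scatter) and, against compound 3, no change at the digits printed from compound 3 to compound 4 (within the scatter) so that a non-aromatic ring with no imidazole matches it in this assay. Nothing available explains why this change has the effect it does.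

The step to compound 4 moves the ring attachment, adds the 3,3-dimethylbutyl chain on the ring nitrogen and introduces the stereocentre all at once, so the compounds shown do not separate these contributions. A 1-methylpyrrolidin-2-yl group, a pyrrolidin-2-yl group with a free ring amine, or the mirror-image form of the group in compound 4 would be needed to tell which of them carries the gain.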